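From Hydroxy to Butyl on a Shared Core

The source may report more compounds than this note shows. Statements on the series, on what has been measured and on what is new or still open speak of the compounds shown alone.

Compound 1 `Cc1ccccc1C[C@H]1COC[C@@H]1Cc1ccc(Cl)c(Cl)c1`: 21000 nM
Compound 2 `Oc1ccc(C[C@H]2COC[C@@H]2Cc2ccc(Cl)c(Cl)c2)cc1`: 31000 nM
Compound 3 `CCCCc1ccc(C[C@H]2COC[C@@H]2Cc2ccc(Cl)c(Cl)c2)cc1`: not yet measured

The measurements so far come from a functional assay on HL-60 cells (Homo sapiens) for cytotoxicity, read by WST assay, with a stated time of 48 h; a higher number here means that more compound is needed for the effect, a lower number that less compound is needed. Going by the values given here, compound 2 stands level with the only other measured compound, since the single measured step, a 1.5-fold higher number from compound 1 to compound 2 (0.17 log units; within the scatter), does not exceed the usual scatter.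

Compound 3 keeps the shared core and differs from compound 2 in one place: butyl in place of hydroxy on an aromatic carbon, para to a large group (butyl in place of hydroxy on an aromatic carbon).

Among the compounds with values here, no measured compound carries butyl, so no step shows this change directly. The nearest guide is the step already described, which replaced 2-methylphenyl with 4-hydroxyphenyl and left the numbers within the scatter. One small step is thin evidence, but it gives no reason to expect a large move in this assay, so no shift beyond the scatter is expected in either direction. The expected change is a 1.4-fold lower number from compound 2 to compound 3 (0.15 log units; within the scatter). For compound 3, the estimated value is 22000 nM, with an expected range from 8000 nM to 55000 nM.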

Compound 3, half-maximal effective concentration: 23000 nM
Compound 3: the middle estimate sits 1.0-fold (0.02 log units) below what was measured; the measured number falls inside the stated range.
By their numbers in this assay, from the lowest: compounds 1, 3 and 2 (each within the scatter of the next).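

In this assay the swap of hydroxy for butyl on an aromatic carbon, para to a large group, gives a 1.3-fold lower number from compound 2 to compound 3 (0.13 log units; within the scatter) and so leaves the number level, with the rest of the molecule held fixed. On paper this is a sizeable change: 1 heavy atom with 1 hydrogen-bond donor and 1 hydrogen-bond acceptor leaves, while 4 heavy atoms with 0 hydrogen-bond donors and 0 hydrogen-bond acceptors enter, so in these compounds the number does not depend on keeping the hydroxy at this place, and a butyl chain there is accepted without a shift beyond the scatter. No separate measurement is available to explain why the number stays level across this swap.

As far as these compounds go, it remains open whether any group at this place can move the number beyond the scatter, for example an amine, a carboxylic acid or a chain longer than butyl. From the compounds shown here alone, it is also open whether the same swap would leave the number level on a core other than the shared one, since this single step speaks only for the shared core.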